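Methoxy on the Core: a Cytotoxicity Step from Compound 1

This account rests on a few compounds, and the source may have more. Where it says the series, first, only, none or still open, it means among the compounds named here.

Compound 1 `COc1cc(/C(Cl)=C/C=C(\C#N)C(=O)c2c[nH]c3ccccc23)cc(OC)c1OC` was tested in an ADME assay on Vero cells (Chlorocebus sabaeus) for cytotoxicity, read by sulforhodamine B assay, with a stated time of 48 h (on this read-out lower numbers stand for stronger inhibition of growth and higher numbers for weaker inhibition of growth), where compound 1 gives 35900 nM. Its closest measured relative is compound 3 `COc1cc(/C(Cl)=C/C=C(\C#N)C(=O)c2c(C)[nH]c3ccccc23)cc(OC)c1OC`, which in this assay gives 42600 nM; the two lie within the scatter of each other, as the step of a 1.2-fold higher number from compound 1 to compound 3 (0.07 log units; within the scatter) shows, a methyl in place of hydrogen on an aromatic carbon of the core leaving the number essentially unchanged. Compound 2 `COc1ccc(/C(Cl)=C/C=C(\C#N)C(=O)c2c[nH]c3ccccc23)cc1` belongs to the same series, but in this assay compound 2 gives "not determined" (no result reported), so it offers no number to compare.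

Compound 4 `COc1ccc2[nH]cc(C(=O)/C(C#N)=C/C=C(\Cl)c3cc(OC)c(OC)c(OC)c3)c2c1` differs from compound 1 by methoxy in place of hydrogen on an aromatic carbon. Among the compounds with values here, the only measured step that bears on a substitution at the core is the one from compound 1 to compound 3, which stayed within the scatter. On that basis no step beyond the scatter is expected for compound 4 in this assay, and the estimated step of a 1.1-fold higher number from compound 1 to compound 4 (0.02 log units; within the scatter) is taken as small. Compound 4 is therefore expected to give about 38000 nM, with a range from 19000 nM to 76000 nM.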

Compound 4, concentration for total growth inhibition: 12100 nM
For compound 4 the middle estimate is 3.1-fold (0.50 log units) above the measured one; measured number below the stated range.
By their numbers in this assay, from the lowest: compound 4; then compounds 1 and 3 (each within the scatter of the next).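

The step of a 3.0-fold lower number from compound 1 to compound 4 (0.47 log units; beyond the scatter) shows that this position on the core is not silent in this assay, where methoxy on an aromatic carbon that is meta to a fused ring and para to a fused ring gives stronger inhibition of growth. The earlier change on the core, a 1.2-fold higher number from compound 1 to compound 3 (0.07 log units; within the scatter), a methyl in place of hydrogen at a different place, had not shown that a single substitution there could move the number beyond the scatter. Nothing measured here explains this step, which rests on one pair of compounds.

From the compounds shown here alone, whether the lower number belongs to methoxy itself, or would also follow with hydroxy, a fluorine atom or an amine on the same aromatic carbon, remains open. So does whether a longer chain such as ethoxy there would carry the step further.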